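Compound 1 to compound 4: one added methoxy

The source may report more compounds than this note shows. Statements on the series, on what has been measured and on what is new or still open speak of the compounds shown alone.

In a functional assay on HUVEC cells (Homo sapiens) for inhibition, with a stated time of 4 days (a lower number here means a stronger inhibitor, a higher number a weaker inhibitor), compound 1 `COc1ccc(C(N)=O)cc1/C=C/c1ccccc1` gives 2400 nM and sits level with compound 2 `COc1ccc(C(N)=O)cc1/C=C/c1ccc(F)cc1` at 2100 nM while compound 3 `COc1ccc(C(N)=O)cc1/C=C/c1cccc(Cl)c1` reads higher at 24000 nM on the same scale. The change to compound 4 `COc1ccccc1/C=C/c1cc(C(N)=O)ccc1OC` is methoxy in place of hydrogen on an aromatic carbon and it sits ortho to a large group. Going by the values given here, two measured steps bear on it: fluoro in place of hydrogen gives a 1.1-fold lower number from compound 1 to compound 2 (0.06 log units; within the scatter) and chloro in place of hydrogen gives a 10-fold higher number from compound 1 to compound 3 (1.00 log units; beyond the scatter) and neither involves a methoxy. A modest rise in the number is therefore expected, with the estimated step being a 2.1-fold higher number from compound 1 to compound 4 (0.32 log units; beyond the scatter) overall. For compound 4 the estimated value is 5000 nM with an expected range from 1500 nM to 20000 nM in this measurement.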

Compound 4, half-maximal inhibitory concentration: 5700 nM
Compound 4: middle estimate off by 1.1-fold (0.06 log units), on the low side, and the stated range covers the measured number.
By their numbers in this assay, from the lowest: compounds 2 and 1 (each within the scatter of the next); then compound 4; then compound 3.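

In this assay, methoxy in place of hydrogen on an aromatic carbon, ortho to a large group, gives a 2.4-fold higher number from compound 1 to compound 4 (0.38 log units; beyond the scatter). Going by these compounds alone, this is the first step here with a substituent other than a halogen, and it shows that a methoxy at this place costs only a modest rise in the number, unlike the larger 10-fold higher number from compound 1 to compound 3 (1.00 log units; beyond the scatter). Nothing available here accounts for this rise.

The compounds shown leave open how a hydroxyl, an amine or a longer chain such as ethoxy would read at this place. They also leave open whether methoxy would give a similar step on another carbon of that ring.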